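A few compounds are considered here, and "the series" means these few. Any claim that something is new, unique, unknown or untested is made for them only; others in the source may bear on it.

Measured compounds:
compound 1 `COc1cc(Cc2cnc(/N=C3\C(=O)N(CN4CCN(Cc5ccccc5)CC4)c4ccc(Cl)cc43)nc2N)cc(OC)c1OC` gives 36.1 ug/mL
compound 2 `COc1cc(Cc2cnc(/N=C3\C(=O)N(CN4CCN(C)CC4)c4ccc(Cl)cc43)nc2N)cc(OC)c1OC` gives 80.7 ug/mL
compound 3 `COc1cc(Cc2cnc(/N=C3\C(=O)N(CN4CCN(c5cc6c(cc5F)c(=O)c(C(=O)O)cn6C5CC5)CC4)c4ccc(Cl)cc43)nc2N)cc(OC)c1OC` gives 187 ug/mL

All three were read in an ADME assay on MT4 cells (Homo sapiens) for cytotoxicity, read by MTT assay, with a stated time of 5 days; a lower number here means that less compound is tolerated, a higher number that more compound is tolerated. Compound 2 stands second highest of the three numbers: compound 1 lies on the lower side of it, while compound 3 gives the highest number of the set, and each of those gaps is beyond the scatter. For the measured compounds named here, the only single-point step among the measured compounds is a 2.2-fold higher number from compound 1 to compound 2 (0.35 log units; beyond the scatter), in which a phenyl was removed from the saturated chain carbon on the ring nitrogen and more compound was tolerated.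

The new compound, compound 4 `COc1cc(Cc2cnc(/N=C3\C(=O)N(CN4CCN(c5ccccn5)CC4)c4ccc(Cl)cc43)nc2N)cc(OC)c1OC`, differs from compound 2 by pyridin-2-yl in place of methyl on an amine nitrogen in a ring. This step bears on the measured one only loosely: it returns an aromatic ring to the same ring nitrogen, though attached directly rather than through a chain carbon, and a ring of the pyridine type rather than a phenyl. Taking a 2.2-fold higher number from compound 1 to compound 2 (0.35 log units; beyond the scatter) as the nearest guide, a modest step toward a lower number is expected for compound 4, while the high value of compound 3, carrying a much larger aryl group at the same place, leaves the direction uncertain. The expected step is a 1.6-fold lower number from compound 2 to compound 4 (0.21 log units; within the scatter). Compound 4 is therefore estimated at 50 ug/mL, with a range from 20 ug/mL to 130 ug/mL.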

Compound 4, half-maximal cytotoxic concentration: 39.2 ug/mL
For compound 4 the middle estimate is 1.3-fold (0.11 log units) above the measured one; measured number inside the range.
By their numbers in this assay, from the lowest: compounds 1 and 4 (each within the scatter of the next); then compound 2; then compound 3.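

In this assay the exchange of methyl for pyridin-2-yl on the amine nitrogen in the ring gives a 2.1-fold lower number from compound 2 to compound 4 (0.31 log units; beyond the scatter) and so shows that a lower number at this position does not depend on the chain carbon of the benzyl group in compound 1. Set against benzyl, pyridin-2-yl gives a 1.1-fold higher number from compound 1 to compound 4 (0.04 log units; within the scatter) and the two groups cannot be told apart here, while compound 3, which also carries an aromatic ring directly on this nitrogen, gives 187 ug/mL and goes against any rule that such a ring lowers the number. Nothing shown here offers an explanation for these differences.

The compounds shown leave open whether the nitrogen of the pyridin-2-yl ring counts for anything, a question that a plain phenyl on the same amine nitrogen would address. From the compounds shown here alone, it is also open whether the carboxylic acid of compound 3 goes with its high number or the rest of that large group does, and where a small acyl group such as acetyl on this nitrogen would fall.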